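Swapping the phenyl group on a short-lived compound

The compounds below may be only part of what the source reports. "The series", "measured", "known", "first", "only" and "open" are said of these compounds alone.

compound 1 `Cc1oc(-c2ccc(Cl)c(Cl)c2)nc1CN1CCC(C(=O)NCCCN2C[C@H](C)C[C@H](C)C2)CC1`: > 0.5 h (a limit, not a number)
compound 2 `Cc1oc(-c2c(Br)cccc2Br)nc1CN1CCC(C(=O)NCCCN2C[C@H](C)C[C@H](C)C2)CC1`: 0.035 h
compound 3 `Cc1oc(-c2c(Cl)cccc2C(F)(F)F)nc1CN1CCC(C(=O)NCCCN2C[C@H](C)C[C@H](C)C2)CC1`: 0.03 h

In an ADME assay on microsomes from liver (Rattus norvegicus) for metabolic stability, read by LC-MS, using NADPH, at 37 degrees C (on this read-out higher numbers stand for a longer-lived compound and lower numbers for a shorter-lived compound), compound 3 gives 0.03 h, at the short-lived end of this small set. Its nearest neighbour is close: a 1.2-fold lower number from compound 2 to compound 3 (0.07 log units; within the scatter). Compound 1 stands far away, with an at least 16-fold lower number from compound 1 to compound 3 (1.22 log units; beyond the scatter) and likewise an at least 14-fold lower number from compound 1 to compound 2 (1.15 log units; beyond the scatter).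

Compound 4 `Cc1ccc(-c2nc(CN3CCC(C(=O)NCCCN4C[C@H](C)C[C@H](C)C4)CC3)c(C)o2)cc1` carries 4-methylphenyl in place of 2-chloro-6-(trifluoromethyl)phenyl (4-methylphenyl in place of 2-chloro-6-(trifluoromethyl)phenyl on an aromatic carbon). The closest guide is the change of this same phenyl group in an at least 16-fold lower number from compound 1 to compound 3 (1.22 log units; beyond the scatter). Compound 4 gives up the group of compound 3 but does not regain the group of compound 1, so only part of that large step is expected back, as a rise in this assay. The expected step is a 6.7-fold higher number from compound 3 to compound 4 (0.82 log units; beyond the scatter). The estimate for compound 4 is 0.2 h, with an expected range of 0.06 h to 0.6 h.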

Compound 4, half-life: > 0.5 h
Compound 4: only a limit was reported; the forecaster's own chance of this, stated with the estimate: 30%; middle value at least 2.5-fold (0.39 log units) from the limit.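

Compound 4 lands on the long-lived side in this assay, with an at least 16-fold higher number from compound 3 to compound 4 (1.22 log units; beyond the scatter) and an at least 14-fold higher number from compound 2 to compound 4 (1.15 log units; beyond the scatter). At this position, then, a phenyl group without any halogen, 4-methylphenyl, can serve as well as the 3,4-dichlorophenyl group on the long-lived side of this set. The step between compound 1 and compound 4 cannot be read, as each value is a limit and not a number: the limit of > 0.5 h in this assay, at which 2 of the 4 values shown sit.

From the compounds shown here alone, how long compound 1 and compound 4 really last remains open. So does whether a plain phenyl or a 2-methylphenyl group would join the long-lived or the short-lived compounds.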